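The source may report more compounds than this note shows. Statements on the series, on what has been measured and on what is new or still open speak of the compounds shown alone.

Measured in an assay on isolated protein with metabotropic glutamate receptor 5 (Rattus norvegicus) as the target; on this read-out higher numbers stand for an effect only at larger amounts of compound and lower numbers for an effect already at smaller amounts:

Compound 1 `Cc1ccc(C(=O)Nc2cc(-c3ccccc3)nn2-c2ccccc2)cc1` gives 40 nM.
Compound 2 `O=C(Nc1cc(-c2ccccc2)nn1-c1ccccc1)c1ccccc1` gives 300 nM.
Compound 3 `O=C(Nc1cc(-c2ccccc2)nn1-c1ccccc1)c1ccccc1F` gives 100 nM.

Compound 3 holds the middle number of the three. The two steps that lead to it, a 3.0-fold lower number from compound 2 to compound 3 (0.48 log units; beyond the scatter) and a 2.5-fold higher number from compound 1 to compound 3 (0.40 log units; beyond the scatter), both lie beyond the scatter, while the largest step in this set is a 7.5-fold higher number from compound 1 to compound 2 (0.88 log units; beyond the scatter). Compound 4 `O=C(Nc1cc(-c2ccccc2)nn1-c1ccccc1)c1ccsc1` differs from compound 3 in one place: thiophen-3-yl in place of 2-fluorophenyl on a carbonyl carbon. The two earlier steps that touch the same carbonyl carbon, a 2.5-fold higher number from compound 1 to compound 3 (0.40 log units; beyond the scatter) and a 3.0-fold lower number from compound 2 to compound 3 (0.48 log units; beyond the scatter), were both modest, so a step of that size is the natural expectation here as well. Among the measured compounds shown here, no measured step exchanges the six-membered ring for a five-membered one, so the direction is open. Since compound 2, which also lacks fluoro on this ring, gives 300 nM, a number somewhat higher than that of compound 3 is expected rather than a lower one. Compound 4 is therefore estimated at 200 nM, within 60 nM to 600 nM. The expected step is a 2.0-fold higher number from compound 3 to compound 4 (0.30 log units; within the scatter).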

Compound 4, half-maximal effective concentration: 2900 nM
Estimate against measurement, compound 4: 15-fold (1.16 log units) below; measured number outside the range, above it.
By their numbers in this assay, from the lowest: compound 1; then compound 3; then compound 2; then compound 4.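

Among the compounds shown here, at this carbonyl carbon, the earlier compounds only varied a small group on a phenyl ring, and exchanging the ring itself proves a much larger change: in this assay, thiophen-3-yl in place of 2-fluorophenyl gives (a 29-fold higher number from compound 3 to compound 4 (1.46 log units; beyond the scatter)). The same ring also stands well apart from plain phenyl (a 9.7-fold higher number from compound 2 to compound 4 (0.99 log units; beyond the scatter)) and from 4-methylphenyl (a 73-fold higher number from compound 1 to compound 4 (1.86 log units; beyond the scatter)). All three six-membered rings shown therefore give lower numbers than thiophen-3-yl, so the identity of the ring counts here, not just what it carries.

Going by these compounds, it remains open whether a furan ring, a pyridine ring or thiophen-2-yl at this carbonyl carbon would behave like thiophen-3-yl, or whether a methyl group on the thiophene ring would lower the number as it does on phenyl. Nothing available here explains why this ring exchange has so large an effect.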